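A few compounds are considered here, and "the series" means these few. Any claim that something is new, unique, unknown or untested is made for them only; others in the source may bear on it.

Working notes on the series. Compound 1 `CCCCOc1cc(OC)ccc1C(C)=O`, compound 2 `CCCCCCOc1cc(OC)ccc1C(C)=O` and compound 3 `CCCCCCCCCCCCCCOc1cc(OC)ccc1C(C)=O` share one core and differ only in the length of the saturated chain. In a functional assay, with a stated time of 10 min (on this read-out higher numbers stand for weaker inhibition and lower numbers for stronger inhibition), compound 1 gives 57200000 nM, compound 2 gives 84400000 nM and compound 3 gives 57000000 nM. The step of a 1.5-fold higher number from compound 1 to compound 2 (0.17 log units; within the scatter) is made by ethyl in place of hydrogen on a saturated chain carbon, four bonds along the chain from an oxygen on an aromatic ring. The next step, a 1.5-fold lower number from compound 2 to compound 3 (0.17 log units; within the scatter), is likewise within the scatter. Compound 4 `CCCCCCCCCCCCCCCCOc1cc(OC)ccc1C(C)=O` has not yet been measured in this assay. Among the measured compounds shown here, its change from compound 3 is ethyl in place of hydrogen on a saturated chain carbon, ten or more bonds along the chain from an oxygen on an aromatic ring; this is the same kind of change as the one from compound 1 to compound 2, at a different place along the chain. The difference between the core of compound 3 and the core of compound 1 is not broken down here. The earlier step of a 1.5-fold higher number from compound 1 to compound 2 (0.17 log units; within the scatter) stayed within the scatter. Because compound 3 gives 57000000 nM, close to both other members, the expected step is a 1.1-fold higher number from compound 3 to compound 4 (0.06 log units; within the scatter). Compound 4 is expected to give about 65000000 nM, with a range from 30000000 nM to 150000000 nM.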

Compound 4, half-maximal inhibitory concentration: 61500000 nM
The estimate for compound 4 lay 1.1-fold (0.02 log units) above the measured number; the range from low to high includes it.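

In this assay the new step reads a 1.1-fold higher number from compound 3 to compound 4 (0.03 log units; within the scatter). Ethyl in place of hydrogen on a saturated chain carbon therefore gives a step within the scatter on both cores, and the two steps cannot be told apart: the same change on two cores in this assay, a 1.5-fold higher number (0.17 log units; within the scatter) from compound 1 to compound 2 and a 1.1-fold higher number (0.03 log units; within the scatter) from compound 3 to compound 4, 1.4-fold (0.14 log units) apart, within the scatter of two such steps

Within this series, the change carries from the core of compound 1 to the core of compound 3 without a readable difference. It does not show that the change has any effect on inhibition on either core, and two pairs are too few to say how it would behave on another core.

The compounds shown carry only plain saturated chains on the oxygen, so it remains open whether a longer chain, or a chain carrying an amine or a carboxylic acid, would give a step beyond the scatter. Also open, going by these compounds, is whether the same change would stay within the scatter on a core with a different ketone or ether group.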